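A New Group on the Triple-Bonded Carbon of Compound 2

The compounds below may be only part of what the source reports. "The series", "measured", "known", "first", "only" and "open" are said of these compounds alone.

For the measured compounds named here, in a functional assay on BaF3 cells (Mus musculus) for antiproliferative activity (on this read-out lower numbers stand for an effect already at smaller amounts and higher numbers for an effect only at larger amounts of compound), compound 1 (`CCN1CCN(Cc2ccc(NC(=O)c3ccc(C)c(C#Cc4cnccn4)c3)cc2C(F)(F)F)CC1`) gives 2490 nM, and compound 2 (`CCN1CCN(Cc2ccc(NC(=O)c3ccc(C)c(C#Cc4cnc(N)cn4)c3)cc2C(F)(F)F)CC1`) gives 860 nM, the lower of the two numbers so far. Compound 3 (`CCN1CCN(Cc2ccc(NC(=O)c3ccc(C)c(C#Cc4cnc5[nH]ccc5c4)c3)cc2C(F)(F)F)CC1`) alters compound 2 on a triple-bonded carbon: a group of 9 heavy atoms (7 carbon, 2 nitrogen; one five-membered aromatic ring with 1 hetero atom, one six-membered aromatic ring with 1 hetero atom) in place of a group of 7 heavy atoms (4 carbon, 3 nitrogen; one six-membered aromatic ring with 2 hetero atoms), on a triple-bonded carbon. Going by the values given here, only one measured step bears on this change: a 2.9-fold lower number from compound 1 to compound 2 (0.46 log units; beyond the scatter), with amino in place of hydrogen on an aromatic carbon. That step is modest and concerns a single substituent on the ring that now leaves, whereas here the whole group is exchanged. Among the compounds with values here, it is therefore only a loose guide, and no measured compound carries a group like the one that enters. A modest change in this assay toward a lower number is expected, though the direction is uncertain and a result near compound 2 would not be surprising. The expected change is a 2.2-fold lower number from compound 2 to compound 3 (0.33 log units; beyond the scatter). The estimate for compound 3 is 400 nM, with an expected range from 90 nM to 1800 nM.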

Compound 3, half-maximal effective concentration: 1000 nM
Beside the measured number, compound 3's estimate is 2.5-fold (0.40 log units) below it, within the range that was stated.
By their numbers in this assay, from the lowest: compounds 2 and 3 (each within the scatter of the next); then compound 1.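

Compound 3 shows that the position on a triple-bonded carbon tolerates more than a single substituent change: the whole 5-aminopyrazin-2-yl group gives way to a larger group of one five-membered and one six-membered aromatic ring, and in this assay the outcome is a 1.2-fold higher number from compound 2 to compound 3 (0.07 log units; within the scatter) for this exchange. The group that enters carries 1 hydrogen-bond acceptor where the group that leaves carries 3, with 1 hydrogen-bond donor on each, so these differing acceptor counts go with no separation in this read-out, and the separation from the unsubstituted ring of compound 1 persists, at a 2.5-fold lower number from compound 1 to compound 3 (0.40 log units; beyond the scatter) for the new group. No independent data accompany these numbers to account for either step.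

With so few compounds, the shown set cannot tell whether a plain phenyl group or an aminopyridine on the triple-bonded carbon would stay level with compound 2 and compound 3 or fall back towards compound 1. It also leaves open what an added amine or a carboxylic acid on the two-ring group of compound 3 would do to the number.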